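Methoxy for fluoro: carrying one step onto a new core

The source may report more compounds than this note shows. Statements on the series, on what has been measured and on what is new or still open speak of the compounds shown alone.

Compound 1 `Cc1nc(C#Cc2cccc(F)c2)cs1` gives 23 nM in a functional assay on CHO cells for agonist activity at metabotropic glutamate receptor 5 (Homo sapiens), read by inositol phosphate accumulation; a higher number here means a weaker inhibitor, a lower number a stronger inhibitor. Compound 2 `COc1cccc(C#Cc2csc(C)n2)c1` gives 49 nM in this assay. The change methoxy in place of fluoro on an aromatic carbon made a step of a 2.1-fold higher number from compound 1 to compound 2 (0.33 log units; beyond the scatter). Compound 3 `Cc1nc(C#Cc2cncc(-c3ccc(F)cc3)c2)cs1` gives 162 nM in this assay, the highest number of the three; the difference between its core and that of compound 1 is not broken down here. Compound 4 `COc1ccc(-c2cncc(C#Cc3csc(C)n3)c2)cc1` is not yet measured and differs from compound 3 by methoxy in place of fluoro on an aromatic carbon. This is the same kind of change as from compound 1 to compound 2, not the same: there the group sits meta to a group of 8 heavy atoms, here para to a large group. The earlier change gave a 2.1-fold higher number from compound 1 to compound 2 (0.33 log units; beyond the scatter). A step of comparable size, a 2.0-fold higher number from compound 3 to compound 4 (0.30 log units; within the scatter), is expected for compound 4, with wider uncertainty for the changed place. Compound 4 is estimated at 320 nM, between 120 nM and 900 nM.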

Compound 4, half-maximal inhibitory concentration: 225 nM
The estimate for compound 4 lay 1.4-fold (0.15 log units) above the measured number; the measured number falls inside the stated range.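

In this assay, methoxy in place of fluoro on the second core gave a 1.4-fold higher number from compound 3 to compound 4 (0.14 log units; within the scatter), a step that does not clear the scatter. Set beside the earlier step, it shows no difference in size between the two cores: the same change on two cores in this assay, a 2.1-fold higher number (0.33 log units; beyond the scatter) from compound 1 to compound 2 and a 1.4-fold higher number (0.14 log units; within the scatter) from compound 3 to compound 4, 1.5-fold (0.19 log units) apart, within the scatter of two such steps. The change therefore carries across these two cores without a visible shift, but two pairs set no rule for other cores, and since the group's surroundings also differ between the pairs, any influence of the core cannot be separated from that of place.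

The compounds shown leave open whether a larger alkoxy group, such as ethoxy, or an amine at the same place would behave alike. They also leave open whether methoxy in place of fluoro keeps this step size on any further core.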